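Notes on the aryl group in a two-compound series

A few compounds are considered here, and "the series" means these few. Any claim that something is new, unique, unknown or untested is made for them only; others in the source may bear on it.

In a functional assay on A549 cells (Homo sapiens) for cytotoxicity, read by MTT assay, with a stated time of 72 h (a higher number here means a weaker inhibitor, a lower number a stronger inhibitor), compound 1 (`COc1cc(/C=C/C(=O)Nc2cc3c(Nc4ccc(F)c(Cl)c4)ncnc3cc2O[C@H]2CCOC2)cc(OC)c1OC`) gives 4150 nM. Compound 2 (`COc1cc(/C=C/C(=O)Nc2cc3c(Nc4ccc(F)c(Cl)c4)ncnc3cc2O[C@H]2CCOC2)cc(OC)c1O`) gives 27000 nM, the higher of the two numbers, which makes it the weaker inhibitor of the pair. Within the data shown here, the only measured step, a 6.5-fold higher number from compound 1 to compound 2 (0.81 log units; beyond the scatter), puts hydrogen in place of methyl on an oxygen on an aromatic ring and lies beyond the scatter.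

Compound 3 (`O=C(/C=C/c1ccc(Br)cc1)Nc1cc2c(Nc3ccc(F)c(Cl)c3)ncnc2cc1O[C@H]1CCOC1`) has not yet been measured. Its change from compound 2 is 4-bromophenyl in place of 4-hydroxy-3,5-dimethoxyphenyl on a double-bonded chain carbon bound to a double-bonded chain carbon, with 4-bromophenyl in place of 4-hydroxy-3,5-dimethoxyphenyl on a double-bonded chain carbon bound to a double-bonded chain carbon. Among the measured compounds shown here, no measured step covers a bromine or the loss of the whole substitution pattern, so the evidence is indirect. Against compound 1, compound 2 stands higher at 27000 nM, and compound 3 no longer carries the hydroxy group. A modest move towards a lower number is therefore expected in this assay, with wide uncertainty. The expected change is a 3.9-fold lower number from compound 2 to compound 3 (0.59 log units; beyond the scatter). For compound 3 the estimated value is 7000 nM, with an expected range of 2000 nM to 25000 nM.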

Compound 3, half-maximal inhibitory concentration: 35300 nM
For compound 3 the middle estimate is 5.0-fold (0.70 log units) below the measured one; measured number above the stated range.
By their numbers in this assay, from the lowest: compound 1; then compounds 2 and 3 (each within the scatter of the next).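

The exchange of 4-hydroxy-3,5-dimethoxyphenyl for 4-bromophenyl gives a 1.3-fold higher number from compound 2 to compound 3 (0.12 log units; within the scatter) in this assay, so these two aryl groups cannot be told apart here, although 4-bromophenyl carries no hydrogen-bond donors or acceptors and the group it replaces carries both. Among these compounds, the hydroxy group is therefore not required for a number in this range, while the exchange of 3,4,5-trimethoxyphenyl for 4-bromophenyl gives an 8.5-fold higher number from compound 1 to compound 3 (0.93 log units; beyond the scatter) and leaves compound 1 separated beyond the scatter from both other compounds, which the single earlier step could not show. No supporting measurement bears on this result, and the numbers alone give no explanation of it.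

The compounds shown leave open whether the separation of compound 1 depends on all three methoxy groups, a question that 4-methoxyphenyl or 3,5-dimethoxyphenyl at the same place could address. They also leave open how an unsubstituted phenyl or a 4-chlorophenyl on the double-bonded chain carbon compares with 4-bromophenyl, and so whether the bromine contributes anything to the number for compound 3.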